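Series notes: sulfonamide aryl swap, lipophilicity

The source may report more compounds than this note shows. Statements on the series, on what has been measured and on what is new or still open speak of the compounds shown alone.

Two members of the series have been run in a physicochemical assay for lipophilicity, at pH 7.4; on this read-out lower numbers stand for lower lipophilicity and higher numbers for higher lipophilicity. Compound 1 `Cc1ccc(N(CC(C)C)S(=O)(=O)c2ccc3c(c2)C(=O)CC(C2CCOCC2)O3)c(C)c1` gives 4.28 in this assay. Compound 2 `CCc1ccc(N(CC(C)C)S(=O)(=O)c2ccc3c(c2)C(=O)CC(C2CCN(C(=O)OC(C)(C)C)CC2)O3)cc1` gives 5.1 in this assay. Among the compounds with values here, compound 1 thus stands lowest of the two numbers, and the gap up to compound 2 is beyond the usual scatter of the measurement; the two compounds differ in more than one place, so no single step between them can be read off.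

The next compound, compound 3 `CC(C)CN(c1ccc(F)cc1)S(=O)(=O)c1ccc2c(c1)C(=O)CC(C1CCOCC1)O2`, is not yet measured in this assay. It is derived from compound 1 by one change: 4-fluorophenyl in place of 2,4-dimethylphenyl on a sulfonamide nitrogen. Only the aryl group on the sulfonamide nitrogen is touched; the shared core and the saturated chain carbon on that nitrogen are unchanged.

Within the data shown here, with no comparable step among the measured compounds, the direction is taken from the structures alone. Compound 3 is expected to come out lower than compound 1 in this assay, by a step of a number 0.78 log units lower from compound 1 to compound 3 (beyond the scatter) that should exceed the scatter. Compound 3 is estimated at 3.5 in this assay, within a range from 3 to 4.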

Compound 3, distribution coefficient: 3.48
The estimate for compound 3 lay 0.02 log units above the measured number; measured number inside the range.
By their numbers in this assay, from the lowest: compound 3; then compound 1; then compound 2.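

In this assay the aryl group on the sulfonamide nitrogen is now seen to move the read-out on its own: with the shared core and the saturated chain carbon unchanged, 4-fluorophenyl in place of 2,4-dimethylphenyl gives a number 0.80 log units lower from compound 1 to compound 3 (beyond the scatter). Within the data shown here, this is the first step that can be tied to a single place, as compound 1 and compound 2 differ in more than one. The swap removes 2,4-dimethylphenyl and brings in 4-fluorophenyl as a single change, and nothing at hand explains the size or direction of the step.

The share of the step that belongs to the loss of the two methyl groups and the share that belongs to the entry of fluorine stay unresolved, and a plain phenyl or a 4-methylphenyl on the same nitrogen would separate them. Also open, going by these compounds, are how far the read-out moves with an aryl group carrying a carboxylic acid or an amine, and whether the same swap gives a comparable step on the core of compound 2.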